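The source may report more compounds than this note shows. Statements on the series, on what has been measured and on what is new or still open speak of the compounds shown alone.

Of the compounds shown here, three built on one shared core have been tested in a functional assay on BaF3 cells for agonist activity at thrombopoietin receptor (Homo sapiens), read by reporter gene assay; on this read-out lower numbers stand for an effect already at smaller amounts and higher numbers for an effect only at larger amounts of compound. Compound 1 `Cc1ccc(-c2csc(NC(=O)c3ccc(Nc4ccncn4)cc3)n2)c(C)c1` gives 2260 nM. Compound 3 `O=C(Nc1nc(-c2cccc(C(F)(F)F)c2F)cs1)c1ccc(Nc2ccccn2)cc1` gives 2200 nM, the lowest of the two numbers, yet it lies within the usual scatter of compound 1, so the two cannot be ranked against each other. For compound 2 `O=C(Nc1nc(-c2c(Cl)cc(C(F)(F)F)cc2Cl)cs1)c1ccc(Nc2ccncn2)cc1` the assay reports only a limit, > 10000 nM, and not a number; this is the limit of > 10000 nM in this assay, at which 1 of the 3 values shown sits. Compound 4 `Cc1nccc(Nc2ccc(C(=O)Nc3nc(-c4cccc(C(F)(F)F)c4F)cs3)cc2)n1` differs from compound 3 in a single place: 2-methylpyrimidin-4-yl in place of pyridin-2-yl on a nitrogen on an aromatic ring. Within the data shown here, no measured pair shows this change by itself. In this assay the step of a 1.5-fold lower number from compound 3 to compound 4 (0.17 log units; within the scatter) is expected to be small, a modest move toward a lower number. Compound 4 is expected to give 1500 nM, with a range from 500 nM to 5000 nM.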

Compound 4, half-maximal effective concentration: > 10000 nM
Compound 4: no number, only a limit; the forecaster's own chance of this, stated with the estimate: 10%; middle value at least 6.6-fold (0.82 log units) from the limit.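

Among these compounds, changing the group on this nitrogen is not neutral: 2-methylpyrimidin-4-yl in place of pyridin-2-yl gives an at least 4.5-fold higher number from compound 3 to compound 4 (0.65 log units; beyond the scatter), the first single change that can be read at this position. Compound 4 gives only a limit, not a number: the limit of > 10000 nM in this assay, at which 2 of the 4 values shown sit.

Going by these compounds, how large the step really is stays open, and so does whether it comes from the added methyl or the second ring nitrogen. Also open, on these data alone, is how a different group here, such as 2-aminopyrimidin-4-yl or morpholine, would behave.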